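Replacing a Fluorinated Chain with a Trifluoromethylcyclopropyl Group

The source may hold more compounds than are shown below. What is called first, only, known or untested is meant among the compounds shown, and "the series" means these compounds.

Among the compounds with values here, compound 2 `C[C@H](CF)OC(=O)N1CCC(O[C@H]2CC[C@H](Oc3cnc(S(C)(=O)=O)cn3)CC2)CC1` is one of two compounds measured in a functional assay on isolated protein for agonist activity at Glucose-dependent insulinotropic receptor (Rattus norvegicus), read by HTRF and cAMP accumulation; a lower number here means that less compound is needed, a higher number that more compound is needed for the effect. In that assay compound 2 gives 317 nM, the higher of the two numbers, while compound 1 `CC(C)(C)OC(=O)N1CCC(O[C@H]2CC[C@H](Oc3ccc(C#N)cc3)CC2)CC1` gives 45 nM; the two differ at more than one place, so their gap cannot be tied to a single change. Compound 3 `CS(=O)(=O)c1cnc(O[C@H]2CC[C@H](OC3CCN(C(=O)C4(C(F)(F)F)CC4)CC3)CC2)cn1` differs from compound 2 at one place only: a group of 7 heavy atoms (4 carbon, 3 fluorine; one three-membered non-aromatic ring of carbon only) in place of a group of 5 heavy atoms (3 carbon, 1 oxygen, 1 fluorine; no ring), on a carbonyl carbon, on a carbonyl carbon whose other neighbour is an amide-type nitrogen in a ring. Within the data shown here, no measured pair shows what such a change does at this receptor, so there is no basis for expecting a shift in either direction. The expected change is a 1.1-fold lower number from compound 2 to compound 3 (0.02 log units; within the scatter), not beyond the scatter. Compound 3 is estimated to give about 300 nM, with a range from 100 nM to 900 nM.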

Compound 3, half-maximal effective concentration: 1380 nM
Compound 3: middle estimate off by 4.6-fold (0.66 log units), on the low side; the whole stated range lies below it.
By their numbers in this assay, from the lowest: compound 1; then compound 2; then compound 3.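

In this assay, the group on the carbonyl carbon whose other neighbour is the amide-type nitrogen in a ring clearly matters: with the rest of the molecule unchanged, putting 1-(trifluoromethyl)cyclopropyl in place of the open fluorinated chain gives a 4.4-fold higher number from compound 2 to compound 3 (0.64 log units; beyond the scatter). Within the data shown here, this is the first single-place comparison, and it shows that more compound is needed for the effect after this swap. No measurement at hand explains the shift.

The swap adds a three-membered ring and changes the fluorine count while removing an oxygen and a defined stereocentre, so this one step cannot separate what each of these changes contributes. On these data alone, it also remains open whether a plain cyclopropyl group, without the trifluoromethyl, would give a number closer to that of compound 2 or compound 3.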